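This account rests on a few compounds, and the source may have more. Where it says the series, first, only, none or still open, it means among the compounds named here.

Working notes on the cinnamate ester series.

Compound 1 `COc1cccc([C@H](O)COC(=O)/C=C/c2ccccc2)c1` and compound 2 `O=C(/C=C/c1ccccc1)OC[C@@H](O)c1ccccc1` form the simplest pair. In an ADME assay on Vero cells (Chlorocebus sabaeus) for cytotoxicity, read by MTT assay, with a stated time of 72 h (a higher number here means that more compound is tolerated, a lower number that less compound is tolerated), compound 2 gives 39200 nM, and compound 1 gives 61900 nM; the change between them is methoxy in place of hydrogen on an aromatic carbon, and the step it made is a 1.6-fold higher number from compound 2 to compound 1 (0.20 log units; within the scatter).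

Compound 3 `COc1cc2ccc([C@@H](COC(=O)/C=C/c3cc(OC)c(OC)c(OC)c3)OC(=O)/C=C/c3cc(OC)c(OC)c(OC)c3)cc2cc1OC` carries a different core; the difference between the core of compound 3 and the core of compound 2 is not broken down here. In this assay compound 3 gives 55700 nM, which sits close to the other two values.

Compound 4 `COc1cc(/C=C/C(=O)OC[C@@H](OC(=O)/C=C/c2cc(OC)c(OC)c(OC)c2)c2ccc3c(OC)c(OC)c(OC)cc3c2)cc(OC)c1OC` has not yet been measured in this assay. It differs from compound 3 by methoxy in place of hydrogen on an aromatic carbon. For the measured compounds named here, this is the same kind of change as the one from compound 2 to compound 1, not the same: in compound 1 the incoming methoxy sits meta to a large group on a single ring, whereas in compound 4 it sits on a ring that is part of a fused system of two rings, ortho to a fused ring, ortho to a methoxy group, meta to a fused ring and meta to a methoxy group.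

Going by the values given here, the only measured precedent is the step from compound 2 to compound 1, which stayed within the scatter. On that basis the step from compound 3 to compound 4 in this assay is expected to be a 1.1-fold higher number from compound 3 to compound 4 (0.05 log units; within the scatter), resting on the size of a 1.6-fold higher number from compound 2 to compound 1 (0.20 log units; within the scatter) and on the value of compound 3, 55700 nM. Compound 4 is therefore estimated at 62000 nM, expected to fall between 30000 nM and 125000 nM.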

Compound 4, half-maximal cytotoxic concentration: 47400 nM
Compound 4: middle estimate off by 1.3-fold (0.12 log units), on the high side; the range from low to high includes it.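

The new step is a 1.2-fold lower number from compound 3 to compound 4 (0.07 log units; within the scatter), so on the core of compound 3 methoxy in place of hydrogen on an aromatic carbon again stays within the scatter in this assay. Set beside the earlier step, the two results cannot be told apart: the same change on two cores in this assay, a 1.6-fold higher number (0.20 log units; within the scatter) from compound 2 to compound 1 and a 1.2-fold lower number (0.07 log units; within the scatter) from compound 3 to compound 4, 1.9-fold (0.27 log units) apart, within the scatter of two such steps. For the compounds shown here, for these two pairs, then, the change can be carried from one core to the other without a step that stands out from the scatter in this assay, but this does not show that the change is without effect in the wider series, as it rests on only two pairs, the incoming methoxy stands at a different place in each, and neither step can be given a reliable direction.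

The compounds shown leave open whether a different group in place of that hydrogen, such as an amine, a carboxylic acid or a longer alkoxy chain, would produce a step beyond the scatter in this assay. They also leave open how an amide in place of the ester linkage would behave, as no such compound is among those shown.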